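Sulfonyl for carbonyl on the ring nitrogen: cytotoxicity outlook

The source may hold more compounds than are shown below. What is called first, only, known or untested is meant among the compounds shown, and "the series" means these compounds.

Three members of the series have been examined in an ADME assay on HepG2 2.2.15 cells (Homo sapiens) for cytotoxicity; on this read-out higher numbers stand for lower toxicity in this test and lower numbers for higher toxicity in this test. Compound 1 `CC(C)(C)OC(=O)Nc1ncc(C(Oc2ccc3cc(Br)ccc3c2)c2ccc(Cl)cc2)s1` gives > 50000 nM, which is a limit of this assay and not a number. Compound 2 `O=C(Nc1ncc(C(Oc2ccc3cc(Br)ccc3c2)c2ccc(Cl)cc2)s1)C1CCCO1` is recorded in this assay as "not toxic" (no number reported), with no number given. Compound 3 `O=C(Nc1ncc(C(Oc2ccc3cc(Br)ccc3c2)c2ccc(Cl)cc2)s1)c1ccc(F)cc1` likewise stands in this assay at "not toxic" (no number reported), again without a single number. Thus no numerical position can be assigned to compound 3 among the values shown: one of the three entries is a limit, the other two are qualitative, and nothing places compound 3 apart from compound 1 or compound 2. The one numerical anchor in the set is the limit of > 50000 nM in this assay, at which 1 of the 3 values shown sits.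

Compound 4 `O=S(=O)(Nc1ncc(C(Oc2ccc3cc(Br)ccc3c2)c2ccc(Cl)cc2)s1)c1ccccc1` is not yet measured in this assay. It differs from compound 3 as follows: phenylsulfonyl in place of (4-fluorophenyl)carbonyl on a nitrogen on an aromatic ring. For the measured compounds named here, since no step between measured compounds is available, no size or direction of change in this assay can be read from the data; with all three measured compounds sitting at a limit or recorded as not toxic, no shift beyond the scatter is expected.

Compound 4 is therefore expected to fall in this assay at about 50000 nM, with a range from 20000 nM to 100000 nM, and most likely to be reported only as a limit.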

Compound 4, half-maximal cytotoxic concentration: > 50000 nM
Compound 4 was reported as a limit; the forecaster's own chance of this, stated with the estimate: 80%; the middle value sits exactly at the limit.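

In this assay compound 4 gives > 50000 nM, which is a limit of this assay and not a number. No new step can be read: compound 1 also stands at a limit, and compound 2 and compound 3 carry no number. Whether any group on a nitrogen on an aromatic ring changes the result in this assay stays open, with a single anchor: the limit of > 50000 nM in this assay, at which 2 of the 4 values shown sit.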